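Aryl group on the ring nitrogen: compound 3 to compound 4

The source may hold more compounds than are shown below. What is called first, only, known or untested is meant among the compounds shown, and "the series" means these compounds.

Three compounds of this series share one core and differ only in the aryl group on the amide-type nitrogen of the five-membered ring. In a functional assay on MG-63 cells (Homo sapiens) for inhibition, read by CCK-8 assay, with a stated time of 72 h, tested at 1 uM (a higher number here means more inhibition at the concentration tested (going by the name of the read-out), a lower number less inhibition), compound 3 `O=C(NCCCCc1ccccc1)c1cccc(C2SCC(=O)N2c2ccccc2F)c1` gives 92%. Compound 1 `COc1ccc(OC)c(N2C(=O)CSC2c2cccc(C(=O)NCCCCc3ccccc3)c2)c1` gives 92% in this assay, and compound 2 `COc1cccc(OC)c1N1C(=O)CSC1c1cccc(C(=O)NCCCCc2ccccc2)c1` gives 80%. Compound 3 thus stands level with compound 1, the two together the highest of the three numbers: no change at the digits printed from compound 1 to compound 3 (within the scatter). Compound 2 sits apart: a number 12 percentage points lower from compound 1 to compound 2 (beyond the scatter), and a number 12 percentage points higher from compound 2 to compound 3 (beyond the scatter).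

Compound 4 `COc1c(F)cccc1N1C(=O)CSC1c1cccc(C(=O)NCCCCc2ccccc2)c1` is not yet measured. The change from compound 3 is 3-fluoro-2-methoxyphenyl in place of 2-fluorophenyl on an amide-type nitrogen in a ring. Within the data shown here, the steps that bear on it are the two into compound 3: from a 2,5-dimethoxyphenyl no change, from a 2,6-dimethoxyphenyl a modest rise. The entering group carries one methoxy and one fluorine, and every swap among methoxy- and fluoro-bearing aryls so far has moved the number by a modest step at most, so compound 4 is expected to stay near compound 3, with a possible small drop that stays within the scatter: a number 5 percentage points lower from compound 3 to compound 4 (within the scatter). Compound 4 is estimated at 87%, within 74% to 95%.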

Compound 4, a percentage reported as inhibition, at one concentration (the size of the read-out at that concentration, not a potency): 0%
For compound 4 the middle estimate is 87 percentage points above the measured one, outside the stated range (below it).
By their numbers in this assay, from the lowest: compound 4; then compound 2; then compounds 1 and 3 (each within the scatter of the next).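

The aryl group on this amide-type nitrogen is less forgiving than the first three compounds suggested, as in this assay the 3-fluoro-2-methoxyphenyl group separates sharply from every earlier aryl group: a number 92 percentage points lower from compound 3 to compound 4 (beyond the scatter), a number 92 percentage points lower from compound 1 to compound 4 (beyond the scatter), and a number 80 percentage points lower from compound 2 to compound 4 (beyond the scatter). Carrying methoxy or fluorine on the aryl ring is therefore no guarantee of a high number here, as the 2-fluorophenyl, 2,5-dimethoxyphenyl and 2,6-dimethoxyphenyl groups keep the read-out high while this combination of methoxy and fluorine does not. No data at hand explain the loss.

Open, as far as these compounds go, is whether it follows the fluorine, the methoxy or the pair, with no phenyl group here carrying only one of the two as placed in compound 4. Also open, from the compounds shown here alone, is how the number responds to an ethoxy in place of that methoxy, or an amine in place of that fluorine.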